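The source may hold more compounds than are shown below. What is called first, only, known or untested is meant among the compounds shown, and "the series" means these compounds.

In a functional assay on HL-60 cells (Homo sapiens) for cytotoxicity (a lower number here means a stronger inhibitor, a higher number a weaker inhibitor), compound 1 `COc1ccc(/C=C\c2ccc3c(c2)C(C)(C)CCC3(C)C)cc1N` gives 25000 nM, the lowest of the two plain numbers shown. Compound 2 `C/C(=C/c1ccccc1C(=O)O)c1ccc2c(c1)C(C)(C)CCC2(C)C` gives 52000 nM, a higher number that lies beyond the scatter. Compound 3 `C/C(=C\c1ccccc1C(=O)O)c1ccc2c(c1)C(C)(C)CCC2(C)C` reaches only the limit > 100000 nM of this assay, not a number. For the measured compounds named here, the one measured step, an at least 1.9-fold higher number from compound 2 to compound 3 (0.28 log units; that floor lies within the scatter), rests on the fact that compounds 2 and 3 differ only in the configuration as drawn alone. Compound 4 `CC1(C)CCC(C)(C)c2cc(/C=C\c3cccc(N)c3)ccc21` differs from compound 1 in a single way: hydrogen in place of methoxy on an aromatic carbon. Going by the values given here, no measured step removes a methoxy, so this change has no direct precedent here, and the only known step concerns a drawn configuration rather than a group. A number close to that of compound 1 is therefore expected for compound 4, 30000 nM, between 8000 nM and 100000 nM, a step of a 1.2-fold higher number from compound 1 to compound 4 (0.08 log units; within the scatter) that is expected to stay within the scatter.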

Compound 4, half-maximal inhibitory concentration: 10000 nM
Compound 4: the middle estimate sits 3.0-fold (0.48 log units) above what was measured; the measured number falls inside the stated range.
By their numbers in this assay, from the lowest: compound 4; then compound 1; then compound 2. At a limit, above all of these: compound 3.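

In this assay, replacing the methoxy with hydrogen on this aromatic carbon, ortho to an amino group, gives a 2.5-fold lower number from compound 1 to compound 4 (0.40 log units; beyond the scatter). For the compounds shown here, this is the first change of a group rather than of a drawn configuration, and it shows that the methoxy is not needed here: the compound without it has the lower number.

On these data alone, whether an ethoxy, a fluorine or a hydroxy on this carbon would lower the number further remains open. Nothing measured here explains the step.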